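This account rests on a few compounds, and the source may have more. Where it says the series, first, only, none or still open, it means among the compounds named here.

Compound 1 `COc1ccc(CNC(=O)c2cc3cc(OC)c(OCCCOc4no[n+]([O-])c4S(=O)(=O)c4ccccc4)cc3oc2=O)cc1` gives 560 nM in a functional assay on MCF7 cells (Homo sapiens) for inhibition, read by MTT assay, with a stated time of 48 h; on this read-out lower numbers stand for stronger inhibition and higher numbers for weaker inhibition.
Compound 2 `COc1cc2cc(C(=O)NCc3ccccc3)c(=O)oc2cc1OCCCOc1no[n+]([O-])c1S(=O)(=O)c1ccccc1` gives 740 nM in this assay.

For the measured compounds named here, compound 2 holds the higher of the two numbers, yet the only step known, a 1.3-fold higher number from compound 1 to compound 2 (0.12 log units; within the scatter), lies within the scatter, so the two compounds cannot be set apart. Compound 3 `COc1cc2cc(C(=O)Nc3ccc(F)cc3)c(=O)oc2cc1OCCCOc1no[n+]([O-])c1S(=O)(=O)c1ccccc1` carries 4-fluorophenyl in place of benzyl on an amide-type nitrogen. Going by the values given here, no measured step touches this amide-type nitrogen; the single step known changes a methoxy group on a ring elsewhere and says nothing about this swap. The expectation is therefore no step beyond the scatter, with a wide range. Compound 3 is estimated at 700 nM (range 250 nM to 2000 nM), an expected step of a 1.1-fold lower number from compound 2 to compound 3 (0.02 log units; within the scatter).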

Compound 3, half-maximal inhibitory concentration: 860 nM
Beside the measured number, compound 3's estimate is 1.2-fold (0.09 log units) below it, within the range that was stated.
By their numbers in this assay, from the lowest: compounds 1, 2 and 3 (each within the scatter of the next).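

On the amide-type nitrogen, 4-fluorophenyl in place of benzyl gives a 1.2-fold higher number from compound 2 to compound 3 (0.07 log units; within the scatter) in this assay, and 4-fluorophenyl in place of 4-methoxybenzyl gives a 1.5-fold higher number from compound 1 to compound 3 (0.19 log units; within the scatter). So at this nitrogen, which no earlier step touched, these three groups cannot be told apart by this read-out. No available evidence bears on these results. Still open, from the compounds shown here alone, is whether an amine, a carboxylic acid or a longer chain on the amide-type nitrogen would give a step beyond the scatter.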